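Sulfonamide aryl swap on a piperidinyl ketone series

This account rests on a few compounds, and the source may have more. Where it says the series, first, only, none or still open, it means among the compounds named here.

Three compounds in this series share the same core and differ only in the aryl group on the sulfonyl sulfur. Compound 1 `COc1ccc(S(=O)(=O)NCCN2CCC(CCC(=O)c3cc(Cl)c(N)cc3OC)CC2)cc1` in an assay on HEK293 cells for displacement of a labelled ligand from 5-hydroxytryptamine receptor 6 (Homo sapiens), with a stated time of 60 min, tested at 0.01 uM, in the presence of a further agent that is not named here (on this read-out higher numbers stand for a stronger effect at the one concentration tested and lower numbers for a weaker effect), gives 36%. Compound 2 `COc1cc(N)c(Cl)cc1C(=O)CCC1CCN(CCNS(=O)(=O)c2ccc(C)cc2)CC1` in this assay is reported as "not active" (no number reported). Compound 3 `COc1ccc(S(=O)(=O)NCCN2CCC(CCC(=O)c3cc(Cl)c(N)cc3OC)CC2)c(OC)c1` in this assay is likewise reported as "not active" (no number reported), so no single number stands for it, and it shares this state with one further compound, compound 2. Only compound 1 has a numeric read-out at the concentration tested.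

Compound 4 `COc1cc(N)c(Cl)cc1C(=O)CCC1CCN(CCNS(=O)(=O)c2cc(Br)c(N)c(Br)c2)CC1` is not yet measured. It differs from compound 3 in one place: 4-amino-3,5-dibromophenyl in place of 2,4-dimethoxyphenyl on a sulfonyl sulfur. Nothing in the measured set carries the 4-amino-3,5-dibromophenyl group, so the step from compound 3 to compound 4 cannot be read from a neighbouring pair. Given that compound 3 was reported without a number, any move in this assay would most plausibly be upward or none beyond the scatter, with a modest rise if the new aryl group behaves more like that of compound 1 than those of compounds 2 and 3. Compound 4 is therefore expected to give roughly 20%, with a likely range from 0% to 50% in this assay.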

Compound 4, a percentage reported as inhibition, at one concentration (the size of the read-out at that concentration, not a potency): 52%
For compound 4 the middle estimate is 32 percentage points below the measured one; measured number above the stated range.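

In this assay, replacing the 4-methoxyphenyl group on the sulfonyl sulfur with 4-amino-3,5-dibromophenyl gives a number 16 percentage points higher from compound 1 to compound 4 (beyond the scatter), which shows that this place can carry a ring with a quite different set of substituents and still give a measurable read-out at the one concentration tested. Compound 3 is reported as "not active" (no number reported) and compound 4 gives 52%, so the swap of 2,4-dimethoxyphenyl for 4-amino-3,5-dibromophenyl separates an entry without a number from one with a number, although the steps from compound 2 and compound 3 to compound 4 cannot be read as sizes. Nothing shown here explains why the read-out moves with this change at the sulfonyl sulfur.

The compounds shown leave open whether the amine or the two bromine atoms account for the difference, which a phenyl ring carrying only the amino group, or only the two bromine atoms, would help to separate. They also leave open whether the same ring with chlorine in place of bromine would behave like compound 4, and whether a read-out at one concentration reflects a difference in potency.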